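The compounds below may be only part of what the source reports. "The series", "measured", "known", "first", "only" and "open" are said of these compounds alone.

Measured compounds:
Compound 1, `NC[C@H]1CC[C@H](CN(C[C@H]2Cc3ccccc3CN2)[C@H]2CCCc3cccnc32)CC1`, gives 340 nM in a functional assay on CCRF-CEM cells for antagonist activity at C-X-C chemokine receptor type 4 (Homo sapiens), read by calcium flux, with stated times of 25 min and 90 s; on this read-out higher numbers stand for weaker inhibition and lower numbers for stronger inhibition.
Compound 2, `N[C@H]1CC[C@H](CN(C[C@H]2Cc3ccccc3CN2)[C@H]2CCCc3cccnc32)CC1`, gives 280 nM.
Compound 3, `C/C(=C/CN)CN(C[C@H]1Cc2ccccc2CN1)[C@H]1CCCc2cccnc21`, gives 28 nM.

Compound 3 has the lowest number of the three; compound 2 is nearest at a 10-fold lower number from compound 2 to compound 3 (1.00 log units; beyond the scatter) read backwards, and compound 1 furthest at a 12-fold lower number from compound 1 to compound 3 (1.08 log units; beyond the scatter) read backwards, both beyond the scatter. Compound 4, `N[C@H]1CC[C@H](N(C[C@H]2Cc3ccccc3CN2)[C@H]2CCCc3cccnc32)CC1`, carries a group of 7 heavy atoms (6 carbon, 1 nitrogen; one six-membered non-aromatic ring of carbon only) in place of a group of 6 heavy atoms (5 carbon, 1 nitrogen; no ring), on an amine nitrogen. For the measured compounds named here, two measured steps bear on this: a 12-fold lower number from compound 1 to compound 3 (1.08 log units; beyond the scatter) and a 10-fold lower number from compound 2 to compound 3 (1.00 log units; beyond the scatter), in which a group without a ring replaced a group holding one six-membered non-aromatic ring of carbon only and the number fell sharply. Compound 4 reverses that direction, bringing a six-membered non-aromatic ring of carbon only back, though now on an amine nitrogen rather than on a saturated chain carbon. The step from compound 1 to compound 2, a 1.2-fold lower number from compound 1 to compound 2 (0.08 log units; within the scatter), shows that small changes on the ring itself mattered little. Compound 4 is therefore expected to give a higher number than compound 3, by roughly a 7.9-fold higher number from compound 3 to compound 4 (0.90 log units; beyond the scatter). The estimate for compound 4 is 220 nM, with a range from 60 nM to 800 nM.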

Compound 4, half-maximal inhibitory concentration: 34 nM
For compound 4 the middle estimate is 6.5-fold (0.81 log units) above the measured one, outside the stated range (below it).
By their numbers in this assay, from the lowest: compounds 3 and 4 (each within the scatter of the next); then compounds 2 and 1 (each within the scatter of the next).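

In this assay, a six-membered carbon ring on this amine nitrogen is compatible with a low number: the step is a 1.2-fold higher number from compound 3 to compound 4 (0.08 log units; within the scatter), so 4-aminocyclohexyl and the open-chain group cannot be told apart here. The ring alone therefore does not account for the higher numbers of compound 1 and compound 2. With 4-aminocyclohexyl in place of (4-aminocyclohexyl)methyl there is an 8.2-fold lower number from compound 2 to compound 4 (0.92 log units; beyond the scatter), and the larger replacement gives a 10-fold lower number from compound 1 to compound 4 (1.00 log units; beyond the scatter), so the group's attachment matters among these ring compounds.

Nothing available explains these differences. Still open, going by these compounds, is how a hydroxyl or a carboxylic acid in place of the amine of 4-aminocyclohexyl would read, and whether the two stereocentres of that group matter.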